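The source may report more compounds than this note shows. Statements on the series, on what has been measured and on what is new or still open speak of the compounds shown alone.

Compound 1 `Nc1ncnc2c1c(-c1cnc3[nH]ccc3c1)nn2CCCC(=O)NO` is the starting point of this step. In a functional assay on HepG2 cells (Homo sapiens) for inhibition, read by MTT assay, with a stated time of 72 h (on this read-out lower numbers stand for stronger inhibition and higher numbers for weaker inhibition), compound 1 gives > 50000 nM, which is a limit of the assay and not a number. Compound 2 `Nc1nc2cc(-c3nn(CCCCCC(=O)NO)c4ncnc(N)c34)ccc2o1` gives 1990 nM in this assay. Compound 3 `Nc1nc2cc(-c3nn(CC(=O)NO)c4ncnc(N)c34)ccc2o1` gives > 150000 nM, again a limit of the assay. Going by the values given here, the one measured single-point step, an at least 75-fold higher number from compound 2 to compound 3 (1.87 log units; beyond the scatter), hydroxycarbamoyl in place of 4-(hydroxycarbamoyl)butyl, is what bears on the present change. Compound 4 `CNC(=O)CCCCCCCn1nc(-c2cnc3[nH]ccc3c2)c2c(N)ncnc21` differs from compound 1 by 4-(methylcarbamoyl)butyl in place of hydroxycarbamoyl on a saturated chain carbon, three bonds along the chain from an aromatic nitrogen. Compound 1 already stands at the limit of > 50000 nM in this assay, at which 1 of the 3 values shown sits, so no downward room is visible there. The step is expected to be a step that the limit leaves unreadable from compound 1 to compound 4. Compound 4 is therefore expected to give about 80000 nM, within 20000 nM to 300000 nM, most likely again only a limit.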

Compound 4, half-maximal inhibitory concentration: 5630 nM
Beside the measured number, compound 4's estimate is 14-fold (1.15 log units) above it, and the stated range ends above it.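

In this assay the change gives an at least 8.8-fold lower number from compound 1 to compound 4 (0.94 log units; beyond the scatter), so a terminal hydroxycarbamoyl is not needed for a readable number on the core of compound 1. The true size of this step stays unknown, since the value of compound 1 is only a limit: the limit of > 50000 nM in this assay, at which 1 of the 4 values shown sits.

The change alters chain length and end group together, and the two effects cannot be told apart here. Going by these compounds, how the same long chain behaves on this core when it ends in a hydroxycarbamoyl or a carboxylic acid remains open.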